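Swapping Isopropyl for Indolylmethyl on a Cyclic Peptide Ring

This account rests on a few compounds, and the source may have more. Where it says the series, first, only, none or still open, it means among the compounds named here.

Compound 2 `CC(C)[C@H]1NC(=O)[C@H](CCCNC(=N)N)NC(=O)CNC(=O)C[C@@H](C(=O)O)NC(=O)[C@@H](c2ccccc2)NC1=O` gives 7.3 nM in an assay on a protein complex for binding affinity to integrin alpha-5/beta-1 (Homo sapiens), read by ELISA (a lower number here means a stronger inhibitor, a higher number a weaker inhibitor), the lower of the two numbers measured and therefore the stronger of the two inhibitors. Compound 1 `CC(C)[C@@H]1NC(=O)[C@H](CCCNC(=N)N)NC(=O)CNC(=O)C[C@@H](C(=O)O)NC(=O)[C@@H](c2ccccc2)NC1=O` has the same atoms and bonds and differs only in how one stereocentre at a saturated ring carbon is drawn; in this assay compound 1 gives 115 nM. Among the compounds with values here, the step of a 16-fold lower number from compound 1 to compound 2 (1.20 log units; beyond the scatter) is large, and the only evidence attached to it is the fact that one of compounds 1 and 2 is drawn with a defined configuration and the other without, at the place where they differ. Compound 3 `N=C(N)NCCC[C@@H]1NC(=O)CNC(=O)C[C@@H](C(=O)O)NC(=O)[C@@H](c2ccccc2)NC(=O)[C@@H](Cc2c[nH]c3ccccc23)NC1=O` keeps the configuration of compound 2 and alters a group instead: (1H-indol-3-yl)methyl in place of isopropyl on a saturated ring carbon. Within the data shown here, no measured step exchanges one group for another, and the single step available concerns a stereocentre rather than a group, so it offers no direct guide for this change. Compound 3 is therefore expected near compound 2, with a wide range, at 15 nM, from 3 nM to 80 nM. That expected number means a step of a 2.1-fold higher number from compound 2 to compound 3 (0.31 log units; beyond the scatter).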

Compound 3, half-maximal inhibitory concentration: 5.5 nM
The estimate for compound 3 lay 2.7-fold (0.44 log units) above the measured number; measured number inside the range.
By their numbers in this assay, from the lowest: compounds 3 and 2 (each within the scatter of the next); then compound 1.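

At the saturated ring carbon where the earlier pair differed only in configuration, the group itself can be exchanged for a much larger one: isopropyl has no ring and no hydrogen-bond donor, while (1H-indol-3-yl)methyl has one five-membered aromatic ring, one six-membered aromatic ring and a hydrogen-bond donor. In this assay this exchange gives a 1.3-fold lower number from compound 2 to compound 3 (0.12 log units; within the scatter), which lies within the scatter, so compound 2 and compound 3 cannot be told apart. Nothing at hand explains why so large an exchange leaves the number within the scatter.

The compounds shown leave open whether an amine, a carboxylic acid or a longer chain on this carbon would also stay within the scatter of compound 2. They also leave open whether (1H-indol-3-yl)methyl in the opposite configuration would show a step like a 16-fold lower number from compound 1 to compound 2 (1.20 log units; beyond the scatter).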